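The source may report more compounds than this note shows. Statements on the series, on what has been measured and on what is new or still open speak of the compounds shown alone.

Compound 1 `CCCCCCCCc1ccc(OCC(=O)Cn2nnnc2-c2ccccc2Cl)cc1`: 42%
Compound 2 `CCCCCCCCc1ccc(OCC(=O)Cn2nnnc2-c2cccc(S(=O)(=O)N(C)C)c2)cc1`: 24%

Among the measured compounds shown here, in an ADME assay on S9 fraction from liver (Rattus norvegicus) for metabolic stability, read by LC-MS, using NADPH, with a stated time of 30 min (a lower number here means that less of the compound is left, a higher number that more of the compound is left), compound 2 stands at 24%, the lower of the two numbers measured so far. The next compound, compound 3 `CCCCCCCCc1ccc(OCC(=O)Cn2nnnc2Cc2ccccc2)cc1`, has not yet been measured. It carries benzyl in place of 3-(dimethylsulfamoyl)phenyl, on an aromatic carbon of a five-membered aromatic ring with 4 nitrogen (benzyl in place of 3-(dimethylsulfamoyl)phenyl on an aromatic carbon).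

For the measured compounds named here, only one measured step bears on this change, because it swaps groups at the same place: a number 18 percentage points lower from compound 1 to compound 2 (beyond the scatter). That step was modest. Neither compound carries benzyl, so it offers only a rough guide to size and says little about direction. Going by the values given here, compound 1, at 42%, is the only other number available, so a small upward move from compound 2 seems the most reasonable expectation, smaller than the measured step. The expected change is a number 9 percentage points higher from compound 2 to compound 3 (within the scatter). Compound 3 is therefore expected to give about 33%, with an estimated range from 16% to 50%.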

Compound 3, percent of the compound remaining: 26%
For compound 3 the middle estimate is 7 percentage points above the measured one; low and high end bracket the measured number.
By their numbers in this assay, from the lowest: compounds 2 and 3 (each within the scatter of the next); then compound 1.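

In this assay, the step of a number 2 percentage points higher from compound 2 to compound 3 (within the scatter) shows that this position on the ring can carry two quite different groups with no reading between them: benzyl has fewer heavy atoms than 3-(dimethylsulfamoyl)phenyl and no sulfur, oxygen or hydrogen-bond acceptors. The sulfonyl part of the leaving group is therefore not required for a reading at this level. The step of a number 16 percentage points lower from compound 1 to compound 3 (beyond the scatter) adds a second group beyond the scatter from 2-chlorophenyl, so among these three compounds, compound 1 alone stands apart, with more of the compound left than for either of the others, and nothing measured here explains the difference.

Benzyl differs from 2-chlorophenyl in two ways at once, as it lacks the chlorine and adds a carbon between the rings, so plain phenyl or 2-chlorobenzyl at this position would be needed to separate those two changes. Going by these compounds, it also remains open whether an amine or a carboxylic acid on this ring would move the number, and whether a shorter chain in place of the octyl chain would shift all three readings.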